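A Brominated Phenoxy Compound Meets a Trimethoxyphenyl Change

The compounds below may be only part of what the source reports. "The series", "measured", "known", "first", "only" and "open" are said of these compounds alone.

Values measured in a functional assay on PC-3 cells (Homo sapiens) for cytotoxicity, read by MTT assay, with a stated time of 48 h (a lower number here means a stronger inhibitor, a higher number a weaker inhibitor), are shown here, and each is a limit:
Compound 1 `COc1cc(OC)c(/C=C/C(=O)/C=C/c2cc3ccccc3nc2Cl)c(OC)c1` gives > 10000 nM
Compound 2 `COc1cc(OC)c(/C=C/C(=O)/C=C/c2cc3ccccc3nc2Oc2ccccc2)c(OC)c1` gives > 10000 nM
Compound 3 `COc1ccc(/C=C/C(=O)/C=C/c2cc3ccccc3nc2Oc2ccc(Br)cc2)cc1OC` gives > 10000 nM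

Compound 3 stands at > 10000 nM in this assay, which is a limit and not a number. Going by the values given here, it has no readable place in the order of the set, since the same holds for all the compounds measured so far: the limit of > 10000 nM in this assay, at which 3 of the 3 values shown sit.

Compound 4 `COc1cc(OC)c(/C=C/C(=O)/C=C/c2cc3ccccc3nc2Oc2ccc(Br)cc2)c(OC)c1` is still to be measured. It differs from compound 3 as follows: 2,4,6-trimethoxyphenyl in place of 3,4-dimethoxyphenyl on a double-bonded chain carbon bound to a double-bonded chain carbon. This puts 2,4,6-trimethoxyphenyl in place of 3,4-dimethoxyphenyl.

Among the compounds with values here, the one measured step is a step that the two limits leave unreadable from compound 1 to compound 2. It involves a different change and offers no size to carry over. Compound 2 already carries 2,4,6-trimethoxyphenyl, and it gives > 10000 nM, a limit. On that value, no clear gain is expected, and no direction can be firmly predicted. The expected change is a number no higher from compound 3 to compound 4 (the limit leaves the size open). Compound 4 is estimated at 10000 nM, with an expected range from 4000 nM to 25000 nM.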

Compound 4, half-maximal inhibitory concentration: > 10000 nM
Compound 4 ended at the assay's limit (the forecaster's own chance of this, stated with the estimate: 75%); the middle value sits exactly at the limit.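

In this assay compound 4 gives > 10000 nM, which is a limit. No step linking compound 4 with compound 1, compound 2 or compound 3 can be read, because all four compounds share one limit: the limit of > 10000 nM in this assay, at which 4 of the 4 values shown sit.

The compounds shown leave open how far each one lies from that limit, and whether the 2,4,6-trimethoxyphenyl or bromo change alters the read-out at all.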